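The compounds below may be only part of what the source reports. "The series", "measured", "known", "first", "only" and "open" are said of these compounds alone.

Compounds measured so far:
Compound 1 `CC1CCN(C(=S)SCc2ccc(C(=O)Nc3ccccc3N)cc2)CC1`, 28.1%
Compound 2 `Nc1ccccc1NC(=O)c1ccc(CSC(=S)N(Cc2ccccc2)Cc2ccccc2)cc1`, 11%

In a functional assay on MGC-803 cells (Homo sapiens) for antiproliferative activity, read by CCK-8 assay, with a stated time of 72 h, tested at 2 uM (on this read-out higher numbers stand for a stronger effect at the one concentration tested and lower numbers for a weaker effect), compound 1 gives 28.1%, the higher of the two numbers. Compound 2 gives 11%, and that gap lies beyond the usual scatter of repeated measurements, so compound 1 is the stronger of the pair on this read-out. Both share the same core, and they differ only in the group on the thiocarbonyl carbon.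

Compound 3 `Nc1ccccc1NC(=O)c1ccc(CSC(=S)N2CCc3ccccc32)cc1` has not yet been measured. Set against compound 1, the change is 2,3-dihydro-1H-indol-1-yl in place of 4-methylpiperidin-1-yl on a thiocarbonyl carbon. Among the measured compounds shown here, no step between two measured compounds maps this exact change, so the expectation rests on compound 1 alone and on the spread seen with compound 2. The expected step is a number 3.1 percentage points lower from compound 1 to compound 3 (within the scatter), small and within the scatter in either direction. Compound 3 is therefore estimated at 25%, with a range from 8% to 45%.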

Compound 3, a percentage reported as inhibition, at one concentration (the size of the read-out at that concentration, not a potency): 44%
For compound 3 the middle estimate is 19 percentage points below the measured one; the range from low to high includes it.
By their numbers in this assay, from the lowest: compound 2; then compound 1; then compound 3.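

In this assay, replacing 4-methylpiperidin-1-yl with 2,3-dihydro-1H-indol-1-yl on the thiocarbonyl carbon gives a number 15.9 percentage points higher from compound 1 to compound 3 (beyond the scatter). Among the compounds shown here, this is the first step here that changes one place only, so it ties a shift in the read-out directly to this position. It also shows that this position accepts a group with a six-membered aromatic ring and that the read-out rises with it, although nothing measured here explains the rise.

The compounds shown leave open which part of the entering group goes with the rise: a pyrrolidin-1-yl group would keep the five-membered ring without the aromatic ring, while a methyl(phenyl)amino group would keep the aromatic ring without the five-membered ring. A methoxy group on the aromatic ring would test whether that ring can carry further substitution.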